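Swapping the hydroxy of compound 2 for a nitro

A few compounds are considered here, and "the series" means these few. Any claim that something is new, unique, unknown or untested is made for them only; others in the source may bear on it.

- compound 1 `COC(=O)C1=C(C)NC(=O)NC1c1ccc(OC)cc1`: 1.92 ug/mL
- compound 2 `COC(=O)C1=C(C)NC(=O)NC1c1ccc(O)cc1`: 0.79 ug/mL

Among the compounds with values here, in a functional assay, read by spectrophotometry, with a stated time of 10 min (a higher number here means that more compound is needed for the effect, a lower number that less compound is needed), compound 2 has the lower of the two numbers so far, at 0.79 ug/mL. The next compound to be tested is compound 3 `COC(=O)C1=C(C)NC(=O)NC1c1ccc([N+](=O)[O-])cc1`, which has a nitro in place of hydroxy on an aromatic carbon, para to a large group: nitro in place of hydroxy on an aromatic carbon.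

Within the data shown here, only one measured step bears on this change: a 2.4-fold lower number from compound 1 to compound 2 (0.39 log units; beyond the scatter). It is modest, but it shows that replacing the methyl on that oxygen with hydrogen gave a lower number. Among the measured compounds shown here, compound 3 has no hydroxy at all, and no nitro compound has been measured, so this single step is a limited guide. Based on the value of compound 1, 1.92 ug/mL, a modest to moderate rise in this assay is expected, not a further fall. The expected change is a 3.2-fold higher number from compound 2 to compound 3 (0.50 log units; beyond the scatter). For compound 3 the estimated value is 2.5 ug/mL, with an expected range of 0.9 ug/mL to 7 ug/mL.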

Compound 3, half-maximal effective concentration: 1.71 ug/mL
Compound 3: the middle estimate sits 1.5-fold (0.16 log units) above what was measured; measured number inside the range.
By their numbers in this assay, from the lowest: compound 2; then compounds 3 and 1 (each within the scatter of the next).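

In this assay, replacing the hydroxy with nitro gives a 2.2-fold higher number from compound 2 to compound 3 (0.34 log units; beyond the scatter) and so takes away the advantage seen for compound 2, showing that the lower number does not survive this change on the aromatic carbon para to a large group. Nitro in place of methoxy gives a 1.1-fold lower number from compound 1 to compound 3 (0.05 log units; within the scatter) and leaves compound 1 and compound 3 with no real difference, even though these two groups differ in their atoms, so compound 2, with its hydroxy, is the only one of the three that stands apart in this assay. Nothing measured here explains why hydroxy differs from the other two groups.

Within the data shown here, with only three groups compared at one position, it remains unclear whether hydroxy is unusual in giving a lower number or is simply one of several groups that would do so. As far as these compounds go, an amine or a carboxylic acid at this same place would help to separate those two readings, and it is also open whether hydroxy would give a similar result elsewhere on the ring.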